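The source may report more compounds than this note shows. Statements on the series, on what has been measured and on what is new or still open speak of the compounds shown alone.

Compound 1 `Cc1ccc(O)c(/C=N\NC(=O)c2oc3cccc(O)c3c2C)c1` is the compound of interest here. Going by the values given here, in a functional assay on MGC-803 cells (Homo sapiens) for inhibition, read by MTT assay (on this read-out lower numbers stand for stronger inhibition and higher numbers for weaker inhibition), compound 1 gives 5990 nM, which places it at the top of the two numbers measured so far, although the gap to compound 2 is within the usual scatter. Compound 2 `Cc1c(C(=O)N/N=C\c2cc(Cl)cc(Cl)c2O)oc2cccc(O)c12` gives 4360 nM in this assay. Compound 3 `Cc1c(C(=O)N/N=C\c2cc(Cl)ccc2O)oc2cccc(O)c12` is not yet measured; it differs from compound 1 by chloro in place of methyl on an aromatic carbon. Because compound 2 gives 4360 nM, a chloro-bearing ring of this kind is not expected to move the number beyond the scatter, so the step of a 1.2-fold lower number from compound 1 to compound 3 (0.08 log units; within the scatter) is expected to be small. Compound 3 is estimated at 5000 nM, with a range from 2500 nM to 10000 nM.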

Compound 3, half-maximal inhibitory concentration: 4160 nM
Beside the measured number, compound 3's estimate is 1.2-fold (0.08 log units) above it; measured number inside the range.
By their numbers in this assay, from the lowest: compounds 3, 2 and 1 (each within the scatter of the next).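

In this assay chloro in place of methyl on the aromatic carbon para to a hydroxy group gives a 1.4-fold lower number from compound 1 to compound 3 (0.16 log units; within the scatter) and so shows no difference that can be told from the scatter. Removing the other chloro, with hydrogen in its place, gives a 1.0-fold lower number from compound 2 to compound 3 (0.02 log units; within the scatter) and likewise stands within the scatter. Nothing available here explains these results.

The compounds shown leave open whether an amine or a carboxylic acid at this position would move the number beyond the scatter. As far as these compounds go, a longer chain, such as propyl, remains equally open.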